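Methyl to fluoro on the sulfonyl aryl ring

A few compounds are considered here, and "the series" means these few. Any claim that something is new, unique, unknown or untested is made for them only; others in the source may bear on it.

Compound 2 `COc1cc(Nc2nc3ccccc3nc2S(=O)(=O)c2ccc(C)cc2)cc(OC)c1OC` stands second highest of the three numbers in a functional assay on HL-60 cells (Homo sapiens) for cytotoxicity, read by MTT assay, with a stated time of 72 h (a lower number here means a stronger inhibitor, a higher number a weaker inhibitor), where compound 2 gives 320 nM. Nearest is compound 3 `Cc1ccc(S(=O)(=O)c2nc3ccccc3nc2Nc2ccc(N)cc2)cc1`, which gives 1220 nM; furthest is compound 1 `COc1cc(Nc2nc3ccccc3nc2S(=O)(=O)c2ccc(C)cc2)cc(OC)c1`, which gives 20 nM. Both measured steps concern the ring that carries the methoxy groups or the amino group, not the sulfonyl ring: a 16-fold higher number from compound 1 to compound 2 (1.20 log units; beyond the scatter), and a 61-fold higher number from compound 1 to compound 3 (1.79 log units; beyond the scatter). Compound 4 `COc1cc(Nc2nc3ccccc3nc2S(=O)(=O)c2ccc(F)cc2)cc(OC)c1OC` differs from compound 2 on the other side of the shared core: fluoro in place of methyl on an aromatic carbon. For the measured compounds named here, no measured pair alters that ring, so neither step bears directly on the present change; they show only that this assay answers strongly to changes on the ring bearing the methoxy or amino groups. Going by the values given here, for a swap of one small group for another on the sulfonyl ring, with no precedent, the expectation is a step of no set direction and most likely within the scatter, a 1.1-fold higher number from compound 2 to compound 4 (0.04 log units; within the scatter). Compound 4 is therefore estimated near 350 nM in this assay, with a range from 120 nM to 1000 nM that allows for a modest loss or gain.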

Compound 4, half-maximal inhibitory concentration: 4790 nM
For compound 4 the middle estimate is 14-fold (1.14 log units) below the measured one, outside the stated range (above it).
By their numbers in this assay, from the lowest: compound 1; then compound 2; then compound 3; then compound 4.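

The sulfonyl ring is not a silent part of the series: in this assay, fluoro in place of methyl on an aromatic carbon, para to a large group, gives a 15-fold higher number from compound 2 to compound 4 (1.18 log units; beyond the scatter). The change swaps a single heavy atom for a single heavy atom, with no ring, hydrogen-bond donor, hydrogen-bond acceptor or net charge entering or leaving, yet the step is of similar size to a 16-fold higher number from compound 1 to compound 2 (1.20 log units; beyond the scatter) on the other side of the shared core, and this assay therefore answers to changes on both sides. Nothing available accounts for the distance between the 4-methylphenyl and 4-fluorophenyl sulfonyl compounds.

With only methyl and fluoro shown at this place, it remains open whether the step reflects something particular to methyl or to fluoro, and an ethyl, chloro, methoxy or trifluoromethyl group there would help separate the two readings. Also open, as far as these compounds go, is whether the same swap gives a similar step on the ring of compound 1, which carries two methoxy groups and gives 20 nM.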